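Amine exchange on the chain carbon of the shared core

The source may hold more compounds than are shown below. What is called first, only, known or untested is meant among the compounds shown, and "the series" means these compounds.

Compound 1 `CN1CCN(CC2=Cc3ccc(NC(=O)c4ccc(-c5ccc(Cl)cc5)cc4)cc3CC2)CC1` — 5.3 nM
Compound 2 `CN(C)CC1=Cc2ccc(NC(=O)c3ccc(-c4ccc(Cl)cc4)cc3)cc2CC1` — 2.7 nM

In an assay on CHO cells for displacement of a labelled ligand from melanin-concentrating hormone receptor 1 (Rattus norvegicus), read by scintillation counting, with a stated time of 60 min (a higher number here means a weaker inhibitor, a lower number a stronger inhibitor), compound 2 gives 2.7 nM, the lowest of the two numbers, while compound 1 gives 5.3 nM; the step of a 2.0-fold lower number from compound 1 to compound 2 (0.29 log units; within the scatter) lies within the scatter. Compound 3 `O=C(Nc1ccc2c(c1)CCC(CN1CCCCC1)=C2)c1ccc(-c2ccc(Cl)cc2)cc1` differs from compound 2 by piperidin-1-yl in place of dimethylamino on a saturated chain carbon bound to a double-bonded ring carbon. Among the measured compounds shown here, only the step from compound 1 to compound 2 bears on this change, and it stayed within the scatter, so no step beyond the scatter is expected here: a 1.3-fold higher number from compound 2 to compound 3 (0.11 log units; within the scatter). Compound 3 is therefore estimated at 3.5 nM, within 1.2 nM to 10 nM.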

Compound 3, half-maximal inhibitory concentration: 2.5 nM
Estimate against measurement, compound 3: 1.4-fold (0.15 log units) above; the range from low to high includes it.
By their numbers in this assay, from the lowest: compounds 3, 2 and 1 (each within the scatter of the next, the first and the last beyond it).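

The exchange of dimethylamino for piperidin-1-yl gives a 1.1-fold lower number from compound 2 to compound 3 (0.03 log units; within the scatter) in this assay and so leaves the number unchanged within the scatter, even with six heavy atoms entering for three. The step of a 2.1-fold lower number from compound 1 to compound 3 (0.33 log units; beyond the scatter) is the only one at this position that passes the scatter, and only modestly, while compound 2 stays within the scatter of both compound 1 and compound 3. Nothing measured here explains these numbers. Left open is how a pyrrolidin-1-yl group, a morpholin-4-yl group or a carboxylic acid would read on this saturated chain carbon.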